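Amide-nitrogen substituent change from compound 3 to compound 4

The source may report more compounds than this note shows. Statements on the series, on what has been measured and on what is new or still open speak of the compounds shown alone.

Compound 1 `N[C@H]1CC[C@H](Nc2c(C(=O)NCc3ccc(F)cc3)nc(Br)c3cccnc23)CC1` gives 2000 nM in a functional assay on SK-BR-3 cells (Homo sapiens) for cytotoxicity, read by MTT assay, with a stated time of 72 h; a higher number here means a weaker inhibitor, a lower number a stronger inhibitor.
Compound 2 `N[C@H]1CC[C@H](Nc2c(C(=O)Nc3ccccc3)nc(Br)c3cccnc23)CC1` gives 2000 nM in this assay.
Compound 3 `CN(C)c1ccc(CNC(=O)c2nc(Br)c3cccnc3c2N[C@H]2CC[C@H](N)CC2)cc1` gives "not determined" (no result reported) in this assay.

Compound 3 therefore stands nowhere on the numbers: no value for it was reported in this assay. Within the data shown here, the one measured step, no change at the digits printed from compound 1 to compound 2 (within the scatter), shows that exchanging the group on the amide-type nitrogen left the half-maximal inhibitory concentration unchanged within the scatter.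

Compound 4 `C[C@H](NC(=O)c1nc(Br)c2cccnc2c1N[C@H]1CC[C@H](N)CC1)c1ccc(F)cc1` differs from compound 3 in that place: 1-(4-fluorophenyl)ethyl in place of 4-(dimethylamino)benzyl on an amide-type nitrogen. Among the measured compounds shown here, compound 3 carries no number, so no measured step bears directly on this change, and only the step of no change at the digits printed from compound 1 to compound 2 (within the scatter) informs an expectation; it suggests that substituents on the amide-type nitrogen of this kind shift the value little, and it gives no reason to expect a step beyond the scatter from compound 3 to compound 4.

Compound 4 shares the core of compound 1 and carries a 4-fluorophenyl-bearing group on the amide-type nitrogen, so its value is expected near that of compound 1, 2000 nM. Compound 4 is accordingly estimated at 2000 nM in this assay, with a range from 700 nM to 6000 nM.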

Compound 4, half-maximal inhibitory concentration: 9000 nM
For compound 4 the middle estimate is 4.5-fold (0.65 log units) below the measured one; measured number outside the range, above it.
By their numbers in this assay, from the lowest: compounds 1 and 2 (each within the scatter of the next); then compound 4.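

The result shows that this position is not indifferent to every change: in this assay one methyl in place of hydrogen on the saturated chain carbon bound to the amide-type nitrogen and an aromatic carbon, which turns 4-fluorobenzyl into 1-(4-fluorophenyl)ethyl, gives a 4.5-fold higher number from compound 1 to compound 4 (0.65 log units; beyond the scatter) and so a weaker inhibitor. The exchange of 1-(4-fluorophenyl)ethyl for phenyl likewise gives a 4.5-fold higher number from compound 2 to compound 4 (0.65 log units; beyond the scatter), whereas the earlier exchange of phenyl for 4-fluorobenzyl gave no change at the digits printed from compound 1 to compound 2 (within the scatter) and had suggested that the amide substituent mattered little. Among the three compounds with numbers, then, the branched group alone stands apart from the other two, and nothing shown here gives a measured reason for this.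

What the compounds shown leave open is whether the loss belongs to this one configuration of the new stereocentre or would also appear with the opposite one, and whether an ethyl group or a hydroxymethyl group on the same carbon would go further than methyl. On these data alone, the step from compound 3 to compound 4 cannot be read, so the effect of the 4-(dimethylamino)benzyl group at this place also remains open.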